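Plasma unbound fraction: cyclobutyl to cyclopropylmethyl on the core

A few compounds are considered here, and "the series" means these few. Any claim that something is new, unique, unknown or untested is made for them only; others in the source may bear on it.

Measured so far:
compound 1 `CC(=O)Nc1cc(-c2ccc(N(C)C(=O)c3c(F)cccc3Cl)c(N3CC4CC4C3)c2)n(C2CCC2)n1` — 0.003
compound 2 `CC(=O)Nc1cc(-c2ccc(N(C)C(=O)c3c(C)cccc3F)c(N3CC4CC4C3)c2)n(C(C)C)n1` — 0.011

In an ADME assay on a cell-free system (plasma, Homo sapiens) (on this read-out lower numbers stand for a smaller free fraction and higher numbers for a larger free fraction), compound 1 gives 0.003 and compound 2 gives 0.011. Among the measured compounds shown here, compound 1 thus sits at the lower of the two numbers in this assay, and its gap to compound 2 lies beyond the usual scatter; compound 2 differs from compound 1 in more than one place, so no single step is drawn between them.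

Compound 3 `CC(=O)Nc1cc(-c2ccc(N(C)C(=O)c3c(F)cccc3Cl)c(N3CC4CC4C3)c2)n(CC2CC2)n1` has not yet been measured in this assay. It differs from compound 1 in one place: cyclopropylmethyl in place of cyclobutyl on an aromatic nitrogen, the two having the same atoms joined differently. For the measured compounds named here, no measured pair shows this kind of change, so nothing measured speaks to its size. The expectation is a step of no change at the digits printed from compound 1 to compound 3 (within the scatter), that is, none beyond the scatter. Compound 3 is accordingly expected to give an unbound fraction of about 0.003, within a range of 0.0015 to 0.006.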

Compound 3, unbound fraction: 0.005
For compound 3 the middle estimate is 1.7-fold (0.22 log units) below the measured one, and the stated range covers the measured number.
By their numbers in this assay, from the lowest: compounds 1 and 3 (each within the scatter of the next); then compound 2.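

In this assay, among the compounds shown here, the exchange of cyclobutyl for cyclopropylmethyl on the aromatic nitrogen gives a 1.7-fold higher number from compound 1 to compound 3 (0.22 log units; within the scatter) and so supplies the first one-place step. At this position, a four-membered carbon ring and a three-membered carbon ring on a one-carbon link, built from the same atoms, therefore cannot be told apart on this read-out of the unbound fraction. Nothing available explains this result or bears on it.

Still open, as far as these compounds go, is whether a group of a different kind on the same nitrogen, such as a carboxylic acid, a dimethylamino group or a longer chain, would give a step beyond the scatter. Also open, from the compounds shown here alone, is whether the same exchange gives a similar step when other parts of the shared core carry different groups.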